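Swapping the sulfonamide ring of compound 1

The source may hold more compounds than are shown below. What is called first, only, known or untested is meant among the compounds shown, and "the series" means these compounds.

Among the compounds with values here, in a functional assay on NCI-H460 cells (Homo sapiens) for antiproliferative activity, read by sulforhodamine B assay, with a stated time of 72 h (on this read-out lower numbers stand for stronger inhibition and higher numbers for weaker inhibition), compound 1 (`Cc1cc(C)nc(NS(=O)(=O)c2ccc(Nc3nncc4ccccc34)cc2)n1`) gives 0.8 nM and stands lowest of the three numbers known so far. Compound 3 (`O=C1CS/C(=N/Nc2nncc3ccccc23)N1`) follows at 19 nM and compound 2 (`COc1ccc(NC(=S)NNc2nncc3ccccc23)cc1`) at 39 nM with both gaps to compound 1 beyond the scatter. Compound 4 (`Cc1cc(NS(=O)(=O)c2ccc(Nc3nncc4ccccc34)cc2)no1`) keeps the core of compound 1 but carries 5-methyl-1,2-oxazol-3-yl in place of 4,6-dimethylpyrimidin-2-yl on a sulfonamide nitrogen. Within the data shown here, no measured pair isolates such a change. Compound 1 at 0.8 nM sits far under the other two, so an upward drift seems likelier than a further drop. In this assay the expected change is an estimated step of a 3.8-fold higher number from compound 1 to compound 4 (0.57 log units; beyond the scatter) toward weaker inhibition, modestly beyond the scatter. For compound 4 the estimated value is 3 nM with an expected range from 0.6 nM to 15 nM in this measurement.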

Compound 4, half-maximal inhibitory concentration: 28 nM
Beside the measured number, compound 4's estimate is 9.3-fold (0.97 log units) below it; measured number outside the range, above it.
By their numbers in this assay, from the lowest: compound 1; then compounds 3, 4 and 2 (each within the scatter of the next, the first and the last beyond it).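

The sulfonamide nitrogen proves a sensitive place in this assay: with the core of compound 1 kept, 5-methyl-1,2-oxazol-3-yl in place of 4,6-dimethylpyrimidin-2-yl gives a 35-fold higher number from compound 1 to compound 4 (1.54 log units; beyond the scatter), a large step toward weaker inhibition. This first single-change pair shows that the low number of compound 1 depends on the ring on that nitrogen, not on the core alone. Nothing available explains the loss. The two rings differ in both ring size and methyl groups, and the compounds shown do not separate these. As far as these compounds go, how a pyridin-2-yl or plain phenyl ring on that nitrogen would read also stays open.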